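From 2-phenylethenyl to thiophen-3-yl: an expected small step

The compounds below may be only part of what the source reports. "The series", "measured", "known", "first", "only" and "open" are said of these compounds alone.

Compound 1 `c1ccc(Sc2c(-c3cccc4ccccc34)nc3ccccn23)cc1`: 33100 nM
Compound 2 `C(=C/c1nc2ccccn2c1Sc1ccccc1)\c1ccccc1`: 35500 nM
Compound 3 `COc1cccc(OC)c1-c1nc2ccccn2c1Sc1ccccc1`: 32200 nM

These values come from a functional assay on HeLa cells (Homo sapiens) for inhibition, read by MTT assay, with a stated time of 48 h; on this read-out lower numbers stand for stronger inhibition and higher numbers for weaker inhibition. Compound 2 stands within the usual scatter of both compound 1 and compound 3, and the three cannot be told apart. Compound 4 `c1ccc(Sc2c(-c3ccsc3)nc3ccccn23)cc1` has thiophen-3-yl in place of 2-phenylethenyl on an aromatic carbon. Going by the values given here, no measured pair differs in one place only, and the data show no direct step for such a swap. Since compound 1 gives 33100 nM and compound 3 gives 32200 nM with other groups at this place, no clear change is expected in this assay, in either direction. The expected step is a 1.1-fold lower number from compound 2 to compound 4 (0.03 log units; within the scatter), none beyond the scatter. For compound 4 the estimated value is 33000 nM, with a range of 15000 nM to 70000 nM.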

Compound 4, half-maximal inhibitory concentration: 76000 nM
Estimate against measurement, compound 4: 2.3-fold (0.36 log units) below; measured number outside the range, above it.
By their numbers in this assay, from the lowest: compounds 3, 1 and 2 (each within the scatter of the next); then compound 4.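

In this assay this position turns out not to be indifferent to its group: compounds 1, 2 and 3 carry three different groups here yet stay within the scatter of one another, while replacing 2-phenylethenyl with thiophen-3-yl gives a 2.1-fold higher number from compound 2 to compound 4 (0.33 log units; beyond the scatter). The entering group has 5 heavy atoms against 8 and brings a sulfur atom, but nothing measured here ties the weaker inhibition to either difference. Still open, going by these compounds, is how a plain phenyl, a thiophen-2-yl or a ring bearing an amine would behave at this place.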